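Methyl to tert-Butyl on Two Related Cores

The source may hold more compounds than are shown below. What is called first, only, known or untested is meant among the compounds shown, and "the series" means these compounds.

Compound 1 `Cc1cc2[nH]nc(N)c2c(=O)[nH]1` and compound 2 `CC(C)(C)c1cc2[nH]nc(N)c2c(=O)[nH]1` share one core and differ only by tert-butyl in place of methyl on an aromatic carbon. In an assay on isolated protein for inhibition of MAP kinase-activated protein kinase 5 (Homo sapiens), read by mobility shift assay, tested at 30 uM (a lower number here means less inhibition, a higher number more inhibition at the concentration tested (going by the name of the read-out)), compound 1 gives 8%, and compound 2 gives 1%, so the step is a number 7 percentage points lower from compound 1 to compound 2 (within the scatter). Compound 3 `Cc1cc2nn(-c3ccccc3)c(N)c2c(=O)[nH]1` is built on a second core; the difference between the two cores is not broken down here. In this assay compound 3 gives 5%, a number within the scatter of both compound 1 and compound 2, so none of the three can be ordered against the others. Compound 4 `CC(C)(C)c1cc2nn(-c3ccccc3)c(N)c2c(=O)[nH]1` has not yet been measured. It differs from compound 3 by tert-butyl in place of methyl on an aromatic carbon, and the place is described in the same words as for the change from compound 1 to compound 2, so it is the same change made on the second core. The expected step is a number 3 percentage points lower from compound 3 to compound 4 (within the scatter), a small one, because a number 7 percentage points lower from compound 1 to compound 2 (within the scatter) was itself within the scatter. In this assay compound 4 is therefore estimated at 2%, with a range from -6% to 10%.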

Compound 4, a percentage reported as inhibition, at one concentration (the size of the read-out at that concentration, not a potency): 2%
For compound 4 middle estimate and measured number coincide at the digits printed; measured number inside the range.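

In this assay, tert-butyl in place of methyl on an aromatic carbon of the second core gives a number 3 percentage points lower from compound 3 to compound 4 (within the scatter), and this step cannot be told apart from the one on the first core: the same change on two cores in this assay, a number 7 percentage points lower (within the scatter) from compound 1 to compound 2 and a number 3 percentage points lower (within the scatter) from compound 3 to compound 4, 4 percentage points apart, within the scatter of two such steps. As far as these four compounds go, the change reads alike on both cores, with neither step standing out from the scatter. This does not show that a real effect of the change carries from one core to the other, as the agreement is between two steps too small to be read, and it would look the same if the change did nothing on either core.

The compounds shown leave open whether another group on this aromatic carbon, such as an amine, a carboxylic acid or a longer chain, would give a step beyond the scatter in this assay. They also leave open whether tert-butyl in place of methyl would behave alike on a core that gives a clearly higher number.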